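A few compounds are considered here, and "the series" means these few. Any claim that something is new, unique, unknown or untested is made for them only; others in the source may bear on it.

In a functional assay on HepG2 cells (Homo sapiens) for cytotoxicity, read by MTT assay, with a stated time of 72 h (a higher number here means a weaker inhibitor, a lower number a stronger inhibitor), three compounds have been measured: compound 1 (`Nc1ccccc1NC(=O)c1ccc(CNC(=O)c2cc3cccnc3[nH]2)cc1`) at 6100 nM and compound 2 (`Nc1ccccc1NC(=O)c1ccc(NC(=S)NCc2ccccc2F)cc1`) at 5400 nM and compound 3 (`Nc1ccccc1NC(=O)c1ccc(NC(=O)NCc2cccnc2)cc1`) at 5100 nM with nothing to separate them. Compound 2 therefore stands within the usual scatter of both other compounds, and the three numbers cannot be ranked.

The next compound to consider is compound 4 (`Cc1ccc(CNC(=S)Nc2ccc(C(=O)Nc3ccccc3N)cc2)cn1`), which differs from compound 2 in one place. The change is 6-methylpyridin-3-yl in place of 2-fluorophenyl on a saturated chain carbon bound to an amide-type nitrogen and amounts to 6-methylpyridin-3-yl in place of 2-fluorophenyl on a saturated chain carbon bound to an amide-type nitrogen.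

Within the data shown here, no pair of measured compounds differs in one place only, so the data offer no direct precedent for this swap. Among the measured compounds shown here, the only guide is that compound 1 at 6100 nM and compound 3 at 5100 nM stay within the scatter of compound 2 despite their different structures. For that reason, no step beyond the scatter is expected in this assay for this swap. The estimated change is a 1.0-fold higher number from compound 2 to compound 4 (0.01 log units; within the scatter) and would be too small to read as a real difference. Compound 4 is estimated at 5500 nM with an expected range from 2500 nM to 12000 nM in this assay (an expectation, not a measurement).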

Compound 4, half-maximal inhibitory concentration: 11000 nM
Beside the measured number, compound 4's estimate is 2.0-fold (0.30 log units) below it, within the range that was stated.
By their numbers in this assay, from the lowest: compounds 3, 2, 1 and 4 (each within the scatter of the next, the first and the last beyond it).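

Among these compounds, this is the first comparison in this assay between two compounds that differ in one place, and it reads a 2.0-fold higher number from compound 2 to compound 4 (0.31 log units; beyond the scatter), a modest move towards weaker inhibition. The three earlier numbers could not be ranked, but this pair shows that the aromatic group on a saturated chain carbon bound to an amide-type nitrogen can shift the number beyond the usual scatter when the rest of the structure stays the same. The swap removes the fluorine and brings in both a ring nitrogen, counted as a hydrogen-bond acceptor, and a methyl group, while nothing measured here explains the rise.

Because these changes arrive together, this single step cannot show which of them matters, or whether it takes more than one of them to produce the shift. A plain phenyl group at this place would offer a simple reference point, and an amine or a carboxylic acid on the ring would test whether this position tolerates a quite different kind of group in the same cell assay.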